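The source may report more compounds than this note shows. Statements on the series, on what has been measured and on what is new or still open speak of the compounds shown alone.

Measured so far:
- compound 1 `CNC(=O)N1CC1C#N`: 26000 nM
- compound 2 `N#CC1CN1C(=O)Nc1ccc(C(F)(F)F)cc1`: 8200 nM

Two compounds share the core with the nitrile on the small ring and the urea carbonyl on the ring nitrogen. In a functional assay on RPMI-8226 cells (Homo sapiens) for inhibition (on this read-out lower numbers stand for stronger inhibition and higher numbers for weaker inhibition), compound 1 gives 26000 nM, the higher of the two numbers, so the weaker inhibition. Compound 2, carrying an aromatic group bearing trifluoromethyl on the outer urea nitrogen instead of methyl, gives 8200 nM in this assay; the gap between compound 1 and compound 2 lies beyond the scatter. For the measured compounds named here, no single-point step between measured compounds is available.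

Compound 3 `N#CC1CN1C(N)=O` has not been measured in this assay. It differs from compound 1 by hydrogen in place of methyl on an amide-type nitrogen, a small removal that leaves the core and the urea carbonyl unchanged. With only compound 1 as the near neighbour and compound 2 showing that a larger group on that nitrogen goes with the lower number, the step from compound 1 to compound 3 is expected to be small and, if anything, toward a higher number, likely within or close to the scatter.

Compound 3 is expected to give about 35000 nM in this assay, in the range 15000 nM to 80000 nM.

The estimate for compound 3 corresponds to a step of a 1.3-fold higher number from compound 1 to compound 3 (0.13 log units; within the scatter) from compound 1, which is expected to be no more than a marginal loss.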

Compound 3, half-maximal inhibitory concentration: 288000 nM
Compound 3: middle estimate off by 8.2-fold (0.92 log units), on the low side, and the stated range ends below it.
By their numbers in this assay, from the lowest: compound 2; then compound 1; then compound 3.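

In this assay, methyl on this amide-type nitrogen is not a group that can be removed without consequence: hydrogen in its place gives an 11-fold higher number from compound 1 to compound 3 (1.04 log units; beyond the scatter), a large step for the loss of one carbon. Compounds 1 and 2 had shown only that the aromatic group bearing trifluoromethyl goes with a lower number than methyl; compound 3 adds the low end of the comparison, showing that the unsubstituted urea sits well above the methyl compound and that methyl itself already contributes to the read-out. With the same core and urea carbonyl throughout, the order at this one position now runs from compound 2 through compound 1 to compound 3, and nothing available here addresses what lies behind the size of the methyl step.

Still open, going by these compounds, is whether a longer chain such as ethyl or propyl on this nitrogen would continue the move toward lower numbers or whether the aromatic ring is needed to go further. The three compounds also leave open how much of the number for compound 2 belongs to trifluoromethyl, which a plain phenyl group or one bearing a carboxylic acid or an amine would begin to separate from the ring itself.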